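Adding a methoxy group and cytotoxicity on immune cells

A few compounds are considered here, and "the series" means these few. Any claim that something is new, unique, unknown or untested is made for them only; others in the source may bear on it.

Measured compounds:
Compound 1 `CC(=O)Nc1ccc(O)c(C(=O)/C=C/c2ccccc2)c1`: 85500 nM in an ADME assay on THP-1 cells (Homo sapiens) for cytotoxicity, read by flow cytometry and propidium iodide staining, with a stated time of 72 h; on this read-out lower numbers stand for stronger inhibition and higher numbers for weaker inhibition
Compound 2 `COc1ccccc1/C=C/C(=O)c1cc(NC(C)=O)ccc1O`: > 125000 nM in this assay, a limit of the assay
Compound 3 `COc1c(-c2ccccc2)oc2ccc(NC(C)=O)cc2c1=O`: > 125000 nM in this assay, a limit of the assay

Compound 1 and compound 2 differ by methoxy in place of hydrogen on an aromatic carbon. That change gave an at least 1.4-fold higher number from compound 1 to compound 2 (0.16 log units; that floor lies within the scatter). The difference between the core of compound 1 and the core of compound 3 is not broken down here.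

Compound 4 `COc1ccccc1-c1oc2ccc(NC(C)=O)cc2c(=O)c1OC` has not yet been measured in this assay. It differs from compound 3 by methoxy in place of hydrogen on an aromatic carbon, and the place of the change matches word for word the place described for the change from compound 1 to compound 2, so it is the same kind of change on a different core.

The expected step is a step that the limit leaves unreadable from compound 3 to compound 4, because the change is already seen once and two of the three known values sit at the limit of > 125000 nM in this assay, at which 2 of the 3 values shown sit. For compound 4 the estimated value is 150000 nM, expected to fall between 90000 nM and 300000 nM, most likely reported only as a limit.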

Compound 4, half-maximal inhibitory concentration: 108000 nM
Compound 4: the middle estimate sits 1.4-fold (0.14 log units) above what was measured; low and high end bracket the measured number.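

In this assay, swapping phenyl for 2-methoxyphenyl on the core of compound 3 gave an at least 1.1-fold lower number from compound 3 to compound 4 (0.06 log units; that floor lies within the scatter). Set beside the earlier case, this shows that the change can be compared on the two cores only through floors, not through full step sizes: the same change on two cores in this assay, an at least 1.4-fold higher number (0.16 log units; that floor lies within the scatter) from compound 1 to compound 2 and an at least 1.1-fold lower number (0.06 log units; that floor lies within the scatter) from compound 3 to compound 4; the limit leaves it open whether they differ So the pair does not show that the change carries over from one core to the other, nor that it behaves differently on each, and the readings in this series are restricted by a limit of the assay: the limit of > 125000 nM in this assay, at which 2 of the 4 values shown sit.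

The compounds shown leave open whether another group in the same place, such as an amine, a chlorine atom or a carboxylic acid, would give a step that can be read in full on both cores. They also leave open how the methoxy change would compare across cores if both members of each pair gave a real number rather than a limit.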